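Carbamoyl in place of hydroxy-thiadiazolyl on the shared core

The compounds below may be only part of what the source reports. "The series", "measured", "known", "first", "only" and "open" are said of these compounds alone.

The series is read in an assay on microsomes from liver for inhibition of acyl-CoA desaturase 1 (Rattus norvegicus); on this read-out lower numbers stand for stronger inhibition and higher numbers for weaker inhibition. Compound 1 `Oc1nnc(-c2ccc(N3CCC(Oc4ccccc4C(F)(F)F)CC3)nn2)s1` gives 6.1 nM, compound 2 `N#Cc1ccccc1OC1CCN(c2ccc(-n3ccnc3)nn2)CC1` gives 236 nM, and compound 3 `Brc1cccc(OC2CCN(c3ccc(-n4ccnc4)nn3)CC2)c1` gives 23 nM. Compound 1 stands at the lowest of the three numbers; compound 3 is nearest to it and compound 2 furthest, both gaps lying beyond the scatter.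

Within the data shown here, the only step between measured compounds that differ in one place is a 10-fold lower number from compound 2 to compound 3 (1.01 log units; beyond the scatter), a change of the aryl group on the oxygen on the saturated carbon. Compound 4 `O=C(NCCC1CC1)c1ccc(N2CCC(Oc3ccccc3C(F)(F)F)CC2)nn1` differs from compound 1 elsewhere: (2-cyclopropylethyl)carbamoyl in place of 5-hydroxy-1,3,4-thiadiazol-2-yl on an aromatic carbon. Among the measured compounds shown here, no measured step touches this aromatic carbon; compounds 2 and 3 carry a different group there, but no step isolates it. The measured steps therefore give no direct guide to the direction of this change.

For the measured compounds named here, with no bearing step, the estimate for compound 4 is set near compound 1 with a wide range, allowing a moderate weakening: compound 4 is expected at 15 nM, between 4 nM and 60 nM, which means an expected step of a 2.5-fold higher number from compound 1 to compound 4 (0.39 log units; beyond the scatter).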

Compound 4, half-maximal inhibitory concentration: 14 nM
Beside the measured number, compound 4's estimate is 1.1-fold (0.03 log units) above it; low and high end bracket the measured number.
By their numbers in this assay, from the lowest: compound 1; then compounds 4 and 3 (each within the scatter of the next); then compound 2.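

In this assay, among these compounds, exchanging 5-hydroxy-1,3,4-thiadiazol-2-yl for (2-cyclopropylethyl)carbamoyl on the aromatic carbon gives a 2.3-fold higher number from compound 1 to compound 4 (0.36 log units; beyond the scatter) and so provides the first reading at this position. The step is modest, though beyond the scatter. In this pair, the five-membered aromatic ring with 3 hetero atoms can therefore be replaced by a carbamoyl group carrying a three-membered carbon ring at the cost of only a modest rise in the number. Nothing at hand gives a reason for this rise.

Open, going by these compounds, is how a carboxylic acid, an unsubstituted carbamoyl or a longer chain ending in phenyl would read at this aromatic carbon on the core of compound 1. Also open, on these data alone, is whether the same exchange gives a similar step alongside the 3-bromophenyl group of compound 3.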